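A Methyl Removed Where Nothing Yet Binds

The source may report more compounds than this note shows. Statements on the series, on what has been measured and on what is new or still open speak of the compounds shown alone.

Compound 1 `Cc1cnn(C(=O)N(C)CCN(C)Cc2cccc(OCc3ccccc3)c2)c1` was tested in an assay on membranes from brain for binding affinity to neutral cholesterol ester hydrolase 1 (Mus musculus), read by fluorescence, with stated times of 1 h and 30 min; a lower number here means a stronger inhibitor, a higher number a weaker inhibitor. In this assay compound 1 gives only a limit, > 100000 nM. Compound 2 `CN(CCN(C)C(=O)n1cccn1)Cc1cccc(OCc2ccccc2)c1` differs from it by hydrogen in place of methyl on an aromatic carbon. In this assay compound 2 likewise gives only a limit, > 100000 nM. The step that the two limits leave unreadable from compound 1 to compound 2 therefore cannot be read, because the limit of > 100000 nM in this assay, at which 2 of the 3 values shown sit, caps both values. Compound 3 `Cc1cnn(C(=O)N(C)CCN(C)C(c2ccc(OCc3ccccc3)cc2)c2ccc(OCc3ccccc3)cc2)c1` carries another core; how its core differs from that of compound 1 is not broken down here. In this assay compound 3 gives only a limit, > 1000000 nM. Compound 4 `CN(CCN(C)C(c1ccc(OCc2ccccc2)cc1)c1ccc(OCc2ccccc2)cc1)C(=O)n1cccn1` is related to compound 3 by the same change, (hydrogen in place of methyl on an aromatic carbon). Compound 4 is expected to give 1000000 nM, between 100000 nM and 10000000 nM. The expected step of a number no higher from compound 3 to compound 4 (the limit leaves the size open) is set near zero, since the earlier step that the two limits leave unreadable from compound 1 to compound 2 showed no readable gain from this change.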

Compound 4, half-maximal inhibitory concentration: > 1000000 nM
Compound 4: no number, only a limit (the forecaster's own chance of this, stated with the estimate: 90%); the middle value sits exactly at the limit.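

Compound 3 and compound 4 both give only limits in this assay, and the step between them cannot be read. The compounds shown leave open whether hydrogen in place of methyl changes inhibition at all.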